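The source may hold more compounds than are shown below. What is called first, only, known or untested is meant among the compounds shown, and "the series" means these compounds.

In a physicochemical assay for lipophilicity, read by HPLC, at pH 7.5 (a higher number here means a more lipophilic compound, a lower number a more polar compound), compound 2 `Cc1c(-c2ccccc2)nc2ccc(C(F)(F)F)cc2c1C(=O)Nc1ccc(C(=O)O)cc1F` gives 2.1 and compound 1 `Cc1c(-c2ccccc2)nc2ccc(Cl)cc2c1C(=O)Nc1ccc(C(=O)O)cc1F` gives 1.9 and so the two lie within the scatter of each other. Compound 3 `Cc1c(-c2ccccc2)nc2ccc(I)cc2c1C(=O)Nc1ccc(C(=O)O)cc1F` carries iodo in place of trifluoromethyl on an aromatic carbon. Among the compounds with values here, the only measured swap at that place gave a number 0.20 log units higher from compound 1 to compound 2 (within the scatter) and involved trifluoromethyl in place of chloro. Iodo itself has no measurement yet, so this small step is only a guide. The estimated step is a number 0.10 log units higher from compound 2 to compound 3 (within the scatter) and no change beyond the scatter is expected. For compound 3 the estimated value is 2.2 with an expected range from 1.9 to 2.5 on this scale.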

Compound 3, distribution coefficient: 2
Compound 3: middle estimate off by 0.20 log units, on the high side, within the range that was stated.
By their numbers in this assay, from the lowest: compounds 1, 3 and 2 (each within the scatter of the next).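

In this assay iodo joins chloro and trifluoromethyl at this place on the shared core, and the reading does not separate the three: the new group gives a number 0.10 log units lower from compound 2 to compound 3 (within the scatter) and also a number 0.10 log units higher from compound 1 to compound 3 (within the scatter). Iodo has one heavy atom and trifluoromethyl has four, yet that difference in count comes with no change beyond the scatter here. Within the data shown here, nothing measured so far offers a reason for this. Going by these compounds, whether an amine, a carboxylic acid or a longer chain at this place would shift the reading beyond the scatter remains open.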